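Extending the Alkyne Chain of Compound 2

The source may report more compounds than this note shows. Statements on the series, on what has been measured and on what is new or still open speak of the compounds shown alone.

In a physicochemical assay for pharmacokinetics, read by LC-MS, in phosphate buffer, tested at 1 uM (a higher number here means that the compound lasts longer, a lower number that the compound disappears faster), compound 1 `C#CC(=O)Nc1cccc2c1cc(C)n2-c1nc2c(c(NCc3ccccc3)n1)CCCC2` gives 0.21 h, while compound 2 `CC#CC(=O)Nc1cccc2c1cc(C)n2-c1nc2c(c(NCc3ccccc3)n1)CCCC2` gives 16.4 h. Among the compounds with values here, compound 2 therefore holds the higher of the two numbers measured so far. Within the data shown here, the only measured step is large, a 78-fold higher number from compound 1 to compound 2 (1.89 log units; beyond the scatter), and it comes from methyl in place of hydrogen on a triple-bonded carbon.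

Compound 3 `CCCC#CC(=O)Nc1cccc2c1cc(C)n2-c1nc2c(c(NCc3ccccc3)n1)CCCC2` takes the chain further: ethyl in place of hydrogen on a saturated chain carbon bound to a triple-bonded carbon. This places ethyl in place of hydrogen on a saturated chain carbon bound to a triple-bonded carbon, so methyl becomes propyl. The measured step bears on this change only loosely, since it replaced a hydrogen on the triple-bonded carbon itself, and that carbon already carries a carbon substituent in compound 2. Among the measured compounds shown here, no measured pair shows what lengthening such a chain does. A repeat of that large step is therefore not expected, and no change beyond the scatter is expected in this assay, with at most a slight drift upward. The expected step is a 1.2-fold higher number from compound 2 to compound 3 (0.09 log units; within the scatter). The estimate for compound 3 is 20 h, with an expected range from 9 h to 45 h.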

Compound 3, half-life: 21.6 h
Estimate against measurement, compound 3: 1.1-fold (0.03 log units) below; the range from low to high includes it.
By their numbers in this assay, from the lowest: compound 1; then compounds 2 and 3 (each within the scatter of the next).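

Compound 2 and compound 3 cannot be told apart in this assay: the step reads a 1.3-fold higher number from compound 2 to compound 3 (0.12 log units; within the scatter) and so stays within the scatter, which shows that going from methyl to propyl at this position leaves the number essentially where compound 2 had it. The large step seen earlier also survives the longer chain, since propyl in place of hydrogen on the triple-bonded carbon gives a 100-fold higher number from compound 1 to compound 3 (2.01 log units; beyond the scatter), and what the two large steps from compound 1 have in common is a carbon substituent on that carbon, whether methyl or propyl. Nothing at hand bears on why the number answers to the presence of that substituent and not to the length of the chain.

As far as these compounds go, it remains open whether the flat response continues with a chain longer than propyl, or holds for a branched group such as isopropyl or a ring such as cyclopropyl in the same place. From the compounds shown here alone, it is equally open whether a chain ending in an amine or a hydroxyl group would keep a number of this size, since all three compounds carry only hydrogen or plain alkyl there.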